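This account rests on a few compounds, and the source may have more. Where it says the series, first, only, none or still open, it means among the compounds named here.

Compound 1 `C=C1C[C@]23C[C@@]1(O)CC[C@@H]2c1cccc(C)c1[C@@H]3Cn1cc(-c2ccc(C)cc2)nn1` is one of three compounds of a shared core that have been tested in a functional assay on HL-60 cells (Homo sapiens) for cytotoxicity, read by MTT assay, with a stated time of 4 days; a lower number here means a stronger inhibitor, a higher number a weaker inhibitor. In this assay compound 1 gives > 20000 nM, which is a limit of the assay and not a number. Compound 2 `Cc1c(O)ccc2c1[C@H](Cn1cc(-c3ccccc3)nn1)[C@@]13CC(=O)[C@@](C)(CC[C@@H]21)C3` carries the same core with a different pattern of substituents. In this assay compound 2 gives > 20000 nM, again a limit. Compound 3 `Cc1ccc(S(=O)(=O)Oc2ccc3c(c2C)[C@H](Cn2cc(-c4ccc(C(F)(F)F)cc4)nn2)[C@@]24CC(=O)[C@@](C)(CC[C@@H]32)C4)cc1` is the third member of the measured set. In this assay compound 3 gives > 20000 nM, also a limit. Among the compounds with values here, compound 1 therefore stands exactly where the other two measured compounds stand, because of the limit of > 20000 nM in this assay, at which 3 of the 3 values shown sit; no compound in the set has yet produced a number in this assay, and no step between measured compounds is available.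

Compound 4 `C=C1C[C@]23C[C@@]1(O)CC[C@@H]2c1cccc(C)c1[C@@H]3Cn1cc(-c2ccc(Cl)cc2)nn1` is the next compound to be measured. Its difference from compound 1 is chloro in place of methyl on an aromatic carbon; read one bond further out, 4-methylphenyl becomes 4-chlorophenyl. With every measured value sitting at the limit, the author expects no step beyond the usual scatter in this assay in either direction. The step expected from compound 1 to compound 4 is a step that the limit leaves unreadable from compound 1 to compound 4. Compound 4 is thus estimated to give 30000 nM, within a range from 12000 nM to 100000 nM, most likely reported once more as a limit.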

Compound 4, half-maximal inhibitory concentration: > 20000 nM
Compound 4 ended at the assay's limit (the forecaster's own chance of this, stated with the estimate: 85%); the middle value lies beyond the limit too.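

In this assay compound 4 gives > 20000 nM, which is a limit of the assay and not a number. No step can be read from compound 1 to compound 4, because both stop at the same limit: the limit of > 20000 nM in this assay, at which 4 of the 4 values shown sit. The compounds shown leave open how methyl and chloro compare here, and whether any compound of the shared core gives a number in this assay.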